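The source may report more compounds than this note shows. Statements on the series, on what has been measured and on what is new or still open speak of the compounds shown alone.

Measured so far:
compound 1 `CC(C)=CCC/C(C)=C/CC/C(C)=C/CSc1ccccc1C(=O)N[C@@H](C)C(=O)OCCOCCOc1no[n+]([O-])c1S(=O)(=O)c1ccccc1` — 8040 nM
compound 2 `CC(C)=CCC/C(C)=C/CC/C(C)=C/CSc1ccccc1C(=O)N1CCC[C@H]1C(=O)OCC#CCOc1no[n+]([O-])c1S(=O)(=O)c1ccccc1` — 3560 nM
compound 3 `CC(C)=CCC/C(C)=C/CC/C(C)=C/CSc1ccccc1C(=O)N[C@@H](C)C(=O)OCC#CCOc1no[n+]([O-])c1S(=O)(=O)c1ccccc1` — 7310 nM

In a functional assay on U-251 cells (Homo sapiens) for cytotoxicity, read by MTT assay, with a stated time of 48 h (on this read-out higher numbers stand for weaker inhibition and lower numbers for stronger inhibition), compound 1 gives the highest of the three numbers. Compound 3 stands nearest to it, and the gap between compound 1 and compound 3 falls within the usual scatter of this assay. Compound 2 gives a lower number, and its gap to compound 1 lies beyond the scatter.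

Compound 4 `CC(C)=CCC/C(C)=C/CC/C(C)=C/CSc1ccccc1C(=O)NCC(=O)OCCOCCOc1no[n+]([O-])c1S(=O)(=O)c1ccccc1` has not yet been measured. It differs from compound 1 in one place: hydrogen in place of methyl on a saturated chain carbon bound to an amide-type nitrogen and a carbonyl carbon. Going by the values given here, no pair of measured compounds shows this change, so the data give no direct guide to its size or direction.

The step of a 1.0-fold lower number from compound 1 to compound 4 (0.00 log units; within the scatter) is expected to stay within the scatter, with no clear direction. Compound 4 is therefore estimated at 8000 nM, with a range from 4000 nM to 16000 nM.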

Compound 4, half-maximal inhibitory concentration: 8580 nM
Compound 4: the middle estimate sits 1.1-fold (0.03 log units) below what was measured; low and high end bracket the measured number.
By their numbers in this assay, from the lowest: compound 2; then compounds 3, 1 and 4 (each within the scatter of the next).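

In this assay, going by these compounds alone, the step of a 1.1-fold higher number from compound 1 to compound 4 (0.03 log units; within the scatter) gives the first direct reading of hydrogen in place of methyl on a saturated chain carbon bound to an amide-type nitrogen and a carbonyl carbon. At this position, and with the rest of compound 1 held constant, the two compounds cannot be told apart. Nothing measured here offers an explanation for this result.

As far as these compounds go, whether a longer chain or a benzyl group at this carbon would give a different number remains open. So does the effect of an amine or a carboxylic acid placed there.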